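The source may hold more compounds than are shown below. What is called first, only, known or untested is meant among the compounds shown, and "the series" means these compounds.

Compound 1 `Cc1ccccc1Nc1nc(Nc2ccccn2)ncc1Cl`: 11200 nM
Compound 2 `CN1CCN(c2ccc(Nc3ncc(Cl)c(NCc4ccc(F)cc4)n3)nc2)CC1`: > 100000 nM (a limit)

In a functional assay on MDA-MB-231 cells (Homo sapiens) for inhibition, read by CCK-8 assay, with a stated time of 48 h (a higher number here means a weaker inhibitor of growth, a lower number a stronger inhibitor of growth), compound 2 has no exact number, only the limit > 100000 nM. Compound 3 `Cc1cccc(Nc2nc(Nc3ccc(N4CCN(C)CC4)cn3)ncc2Cl)c1` differs from compound 2 in one place: 3-methylphenyl in place of 4-fluorobenzyl on a nitrogen on an aromatic ring, with 3-methylphenyl in place of 4-fluorobenzyl on a nitrogen on an aromatic ring. Going by the values given here, no measured pair shows this change directly. Compound 1, which also carries a methylphenyl group on such a nitrogen, gives 11200 nM, so a large move toward stronger growth inhibition is expected. The expected size is an at least 11-fold lower number from compound 2 to compound 3 (1.04 log units; beyond the scatter). For compound 3 the estimated value is 9000 nM, with an expected range of 1800 nM to 45000 nM.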

Compound 3, concentration for 50% growth inhibition: 5270 nM
Compound 3: the middle estimate sits 1.7-fold (0.23 log units) above what was measured; the measured number falls inside the stated range.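

The compounds shown give their first direct reading at this position, on a nitrogen on an aromatic ring. In this assay, 3-methylphenyl in place of 4-fluorobenzyl gives an at least 18-fold lower number from compound 2 to compound 3 (1.27 log units; beyond the scatter), so this one change takes the compound out of the range where no number could be given. The value of compound 2 is a limit and not a number, so the true size of the step stays unknown: the limit of > 100000 nM in this assay, at which 1 of the 3 values shown sits.

The compounds shown do not separate the loss of the fluorine from the change of benzyl to phenyl, and a plain phenyl group on the same nitrogen would bear on that. Going by these compounds, how an amine or a carboxylic acid on that ring would read also stays open.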